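The source may report more compounds than this note shows. Statements on the series, on what has been measured and on what is new or still open speak of the compounds shown alone.

In a functional assay on CCRF-CEM cells (Homo sapiens), read by MTT assay, with a stated time of 72 h (a lower number here means a stronger inhibitor, a higher number a weaker inhibitor), compound 1 (`CNc1ncnc2c1c(-c1ccco1)cn2[C@@H]1O[C@H](CO)[C@@H](O)[C@H]1O`) gives 180 nM. Compound 2 (`CNc1ncnc2c1c(-c1cccs1)cn2[C@@H]1O[C@H](CO)[C@@H](O)[C@H]1O`) gives > 20000 nM, which is a limit and not a number. Compound 3 (`C#Cc1cn([C@@H]2O[C@H](CO)[C@@H](O)[C@H]2O)c2ncnc(NC)c12`) gives > 20000 nM, also a limit. Compound 2 therefore sits at the limit of > 20000 nM in this assay, at which 2 of the 3 values shown sit. Compound 4 (`Cc1ncnc2c1c(-c1cccs1)cn2[C@@H]1O[C@H](CO)[C@@H](O)[C@H]1O`) differs from compound 2 in one place: methyl in place of methylamino on an aromatic carbon. Among the measured compounds shown here, no measured step covers this change. The closest guides are swaps of a different group, an at least 110-fold higher number from compound 1 to compound 2 (2.04 log units; beyond the scatter) and an at least 110-fold higher number from compound 1 to compound 3 (2.04 log units; beyond the scatter), and both are large, so one swap on this core can matter greatly. With compound 2 at its limit, a readable result in this assay could only be a lower number. The expected change is an at least 6.6-fold lower number from compound 2 to compound 4 (0.82 log units; beyond the scatter). For compound 4, the estimated value is 3000 nM, with an expected range of 300 nM to 20000 nM.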

Compound 4, half-maximal inhibitory concentration: > 20000 nM
Compound 4 gave a limit, no number; the forecaster's own chance of this, stated with the estimate: 35%; at least 6.6-fold (0.82 log units) between middle value and limit.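

Compound 2 and compound 4 both stand at a limit in this assay, so the step between them cannot be read. The compounds shown leave open whether methyl in place of methylamino changes activity at all, including alongside the furan-2-yl group of compound 1.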